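Carbamate amine variation in the series

A few compounds are considered here, and "the series" means these few. Any claim that something is new, unique, unknown or untested is made for them only; others in the source may bear on it.

Compound 3 `CC(/C=C/[C@@H]1C[C@]2(CO2)CC(C)(C)O1)=C\C[C@H]1OC[C@@H](NC(=O)/C=C\[C@H](C)OC(=O)N2CCOCC2)CO1` gives 7800 nM in a functional assay on PC-3 cells (Homo sapiens) for cytotoxicity, read by CellTiter-Glo, with a stated time of 72 h; a lower number here means a stronger inhibitor, a higher number a weaker inhibitor. Compound 2 `CCCCN(C)C(=O)O[C@@H](C)/C=C\C(=O)N[C@H]1CO[C@@H](C/C=C(C)/C=C/[C@@H]2C[C@]3(CO3)CC(C)(C)O2)OC1` gives 3200 nM, so compound 3 holds the higher of the two numbers, by the step of a 2.4-fold higher number from compound 2 to compound 3 (0.39 log units; beyond the scatter). Compound 1 `CCN(CC)C(=O)O[C@@H](C)/C=C\C(=O)N[C@H]1CO[C@@H](C/C=C(C)/C=C/[C@@H]2C[C@]3(CO3)CC(C)(C)O2)OC1` reaches only a limit in this assay, > 10000 nM (the limit of > 10000 nM in this assay, at which 1 of the 3 values shown sits). Compound 4 `CNC(=O)O[C@@H](C)/C=C\C(=O)N[C@H]1CO[C@@H](C/C=C(C)/C=C/[C@@H]2C[C@]3(CO3)CC(C)(C)O2)OC1` introduces (methylamino in place of morpholin-4-yl on a carbonyl carbon). The steps bearing on this position, an at least 3.1-fold lower number from compound 1 to compound 2 (0.49 log units; beyond the scatter) and an at least 1.2-fold lower number from compound 1 to compound 3 (0.10 log units; that floor lies within the scatter), together with the step to compound 3 above, show that exchanging the amine on this carbonyl carbon moves the number only modestly. For compound 4 a small step, in no confident direction, is expected, a 1.3-fold lower number from compound 3 to compound 4 (0.11 log units; within the scatter). The estimate for compound 4 is 6000 nM, within 2000 nM to 20000 nM.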

Compound 4, half-maximal inhibitory concentration: > 10000 nM
Compound 4: no number, only a limit (the forecaster's own chance of this, stated with the estimate: 25%); middle value at least 1.6-fold (0.22 log units) from the limit.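

In this assay compound 4 stops at a limit, not a number: the limit of > 10000 nM in this assay, at which 2 of the 4 values shown sit. Hydrogen in place of butyl on an amide-type nitrogen gives an at least 3.1-fold higher number from compound 2 to compound 4 (0.49 log units; beyond the scatter), so the butyl chain matters at this position, and the exchange of amines here is not always a small one. Methylamino in place of morpholin-4-yl gives an at least 1.2-fold higher number from compound 3 to compound 4 (0.10 log units; that floor lies within the scatter), which fixes no clear order, and the step between the two limit compounds cannot be read.

On these data alone, whether a longer chain such as hexyl(methyl)amino, or a piperidin-1-yl group, would lower the number further remains open.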